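A few compounds are considered here, and "the series" means these few. Any claim that something is new, unique, unknown or untested is made for them only; others in the source may bear on it.

Measured so far:
- compound 1 `O=C(O)Cc1sc(Cc2ccc(Cl)cc2)nc1-c1ccccc1`: 88 nM
- compound 2 `O=C(O)Cc1sc(Cc2ccc(Cl)cc2)nc1-c1ccc(Cl)cc1`: 50 nM

Both were tested in an in vitro assay on COS-7 cells for displacement of a labelled ligand from prostaglandin D2 receptor 2 (Homo sapiens); a lower number here means a stronger inhibitor, a higher number a weaker inhibitor. Compound 1 gives 88 nM, the highest of the two numbers shown, with compound 2 nearest to it. Among the measured compounds shown here, the one step between them, a 1.8-fold lower number from compound 1 to compound 2 (0.25 log units; within the scatter), is a substitution on the aromatic ring that is not the one carrying the chlorinated benzyl group, so it does not reach the position that changes next.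

Compound 3 `Cc1ccc(Cc2nc(-c3ccccc3)c(CC(=O)O)s2)cc1` differs from compound 1 in one place: methyl in place of chloro on an aromatic carbon. For the measured compounds named here, no measured step touches this position; the only step known concerns a different ring, and it stayed within the scatter. Methyl and chloro are both single heavy atoms that bring no hydrogen-bond donors or acceptors, so nothing in the data points to a change beyond the scatter in this assay, in either direction.

For compound 3 the expected value in this assay is 100 nM, with a range from 40 nM to 250 nM. This estimate means a step of a 1.1-fold higher number from compound 1 to compound 3 (0.06 log units; within the scatter).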

Compound 3, half-maximal inhibitory concentration: 250 nM
Beside the measured number, compound 3's estimate is 2.5-fold (0.40 log units) below it; the measured number falls inside the stated range.
By their numbers in this assay, from the lowest: compounds 2 and 1 (each within the scatter of the next); then compound 3.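

In this assay, changing 4-chlorophenyl to 4-methylphenyl gives a 2.8-fold higher number from compound 1 to compound 3 (0.45 log units; beyond the scatter) and so shows that this position responds to the identity of its substituent, even for a swap of one heavy atom for another with no hydrogen-bond donors or acceptors on either side. This is the first step shown that clears the scatter, whereas the only earlier one, a 1.8-fold lower number from compound 1 to compound 2 (0.25 log units; within the scatter) on the other aromatic ring, did not, so the position on the benzyl ring now has a measured effect of modest size, and chloro is the better of the two groups tested there. No measured information on these compounds explains why the two groups differ. Going by these compounds, with only chloro and methyl compared at this place, it remains open how a hydrogen, a fluoro, a bromo or a methoxy would rank against them, and so whether chloro improves the number or methyl worsens it. On these data alone, it is also open whether the same swap would give a step of similar size on the core of compound 2, which carries a second chloro.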